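A few compounds are considered here, and "the series" means these few. Any claim that something is new, unique, unknown or untested is made for them only; others in the source may bear on it.

Measured so far:
compound 1 `NC(=O)c1c(NC(=O)c2ccccc2Cl)sc2c1CCN(Cc1ccccc1Cl)C2` gives 4430 nM
compound 2 `NC(=O)c1c(NC(=O)c2ccc(C(F)(F)F)cc2)sc2c1CCN(Cc1ccc(Cl)cc1Cl)C2` gives 10900 nM
compound 3 `NC(=O)c1c(NC(=O)c2ccccc2F)sc2c1CCN(Cc1c(Cl)cccc1Cl)C2` gives 7430 nM

In a functional assay on MKN-74 cells (Homo sapiens) for antiproliferative activity, with a stated time of 24 h (on this read-out lower numbers stand for stronger inhibition and higher numbers for weaker inhibition), compound 1 has the lowest of the three numbers. Compound 3 sits close to it, within the usual scatter of the read-out, while compound 2 lies further off, beyond that scatter. The step examined here goes from compound 1 to compound 4 `NC(=O)c1c(NC(=O)c2ccccc2Cl)sc2c1CCN(C(=S)Nc1ccccc1I)C2`, which has not yet been measured. The change is a group of 10 heavy atoms (7 carbon, 1 nitrogen, 1 sulfur, 1 iodine; one six-membered aromatic ring of carbon only) in place of a group of 8 heavy atoms (7 carbon, 1 chlorine; one six-membered aromatic ring of carbon only), on an amine nitrogen in a ring. Within the data shown here, no measured pair in this set shares this kind of exchange, so there is no precedent to lean on. With the amide portion of the core held the same, compound 4 is expected to stay near compound 1, with a step of a 1.1-fold higher number from compound 1 to compound 4 (0.05 log units; within the scatter) that need not exceed the scatter. Compound 4 is therefore estimated at 5000 nM, within a range from 1500 nM to 16000 nM.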

Compound 4, half-maximal inhibitory concentration: 2630 nM
Beside the measured number, compound 4's estimate is 1.9-fold (0.28 log units) above it; measured number inside the range.
By their numbers in this assay, from the lowest: compounds 4, 1, 3 and 2 (each within the scatter of the next, the first and the last beyond it).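

In this assay, exchanging the 2-chlorobenzyl on the amine nitrogen in a ring for a group carrying sulfur, nitrogen and iodine gives a 1.7-fold lower number from compound 1 to compound 4 (0.23 log units; within the scatter). This first step at the position shows that the read-out does not separate the two groups, although the entering group adds a hydrogen-bond donor and a hydrogen-bond acceptor. No measurement at hand offers an explanation for this result. On these data alone, it remains open how the iodine, sulfur and nitrogen each contribute, and whether a urea or an unsubstituted phenyl would give a similar number.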